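This account rests on a few compounds, and the source may have more. Where it says the series, first, only, none or still open, it means among the compounds named here.

Of the compounds shown here, three that share one core have been tested in a functional assay on the whole organism for inhibition, with Rattus norvegicus as the target, read by paw edema, at a dose of 100 mg/kg by the oral route; a lower number here means less inhibition, a higher number more inhibition at the dose given (going by the name of the read-out). Compound 1 `O=C(NC1CCN(Cc2ccccc2)CC1)c1c(O)c2cccnc2n(-c2ccccc2)c1=O` gives 1.7%. Compound 2 `Cc1ccc(NC(=O)c2c(O)c3cccnc3n(-c3ccccc3)c2=O)cc1` gives -3.5%, and compound 3 `Nc1ccc(NC(=O)c2c(O)c3cccnc3n(-c3ccccc3)c2=O)cc1` gives -5.5%. Compound 3 has the smallest of these three numbers, yet its gaps to compound 2 and to compound 1 both lie within the scatter, so the three are not told apart. Among the compounds with values here, the one measured step, a number 2 percentage points lower from compound 2 to compound 3 (within the scatter), concerns a group on an aromatic carbon and is itself within the scatter. Compound 4 `O=C(NCc1cccnc1)c1c(O)c2cccnc2n(-c2ccccc2)c1=O` differs from compound 3 at the amide-type nitrogen: (pyridin-3-yl)methyl in place of 4-aminophenyl on an amide-type nitrogen. Within the data shown here, no measured step touches this place, and the only known step is small, so no shift beyond the scatter is expected in this assay. Compound 4 is therefore expected to give 0%, between -10% and 12%, meaning an expected step of a number 5.5 percentage points higher from compound 3 to compound 4 (within the scatter).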

Compound 4, a percentage reported as inhibition, in the whole organism at one dose (the size of the read-out at that dose, not a potency): 25.5%
The estimate for compound 4 lay 25.5 percentage points below the measured number; measured number above the stated range.
By their numbers in this assay, from the lowest: compounds 3, 2 and 1 (each within the scatter of the next); then compound 4.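

Replacing 4-aminophenyl with (pyridin-3-yl)methyl on the amide-type nitrogen gives a number 31 percentage points higher from compound 3 to compound 4 (beyond the scatter) and replacing 4-methylphenyl with it gives a number 29 percentage points higher from compound 2 to compound 4 (beyond the scatter) in the same direction. The only earlier step, on an aromatic carbon, stayed within the scatter, so the group on this nitrogen is the first place shown to move the read-out clearly. No measurement here explains the rise.

On these data alone, it remains open whether the ring nitrogen or the extra carbon link matters more. A plain benzyl group on this nitrogen, or a pyridin-3-yl group joined directly to it, would separate the two.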